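Cyclic hydroxy lactam replacing open acetamide on the fused ring

The source may report more compounds than this note shows. Statements on the series, on what has been measured and on what is new or still open speak of the compounds shown alone.

Measured so far:
compound 1 `CC(C)c1noc(N2CCC(Oc3cc(N4CCc5cc(N6CCCS6(=O)=O)ccc54)ncn3)CC2)n1`: 9.7 nM
compound 2 `CC(=O)N(C)c1ccc2c(c1)CCN2c1cc(OC2CCN(c3nc(C(C)C)no3)CC2)ncn1`: 75 nM

In an assay on CHO cells for agonist activity at Glucose-dependent insulinotropic receptor (Homo sapiens), read by a luciferase reporter and cAMP accumulation, with a stated time of 2 h (on this read-out higher numbers stand for an effect only at larger amounts of compound and lower numbers for an effect already at smaller amounts), compound 2 gives 75 nM, the higher of the two numbers; compound 1 gives 9.7 nM. Going by the values given here, the only measured step bearing on the present change is a 7.7-fold higher number from compound 1 to compound 2 (0.89 log units; beyond the scatter), where the ring substituent was exchanged for the open chain. Compound 3 `CC(C)c1noc(N2CCC(Oc3cc(N4CCc5cc(N6CCC(O)CC6=O)ccc54)ncn3)CC2)n1` carries 4-hydroxy-2-oxopiperidin-1-yl in place of acetyl(methyl)amino on an aromatic carbon. Since compound 3 again bears a ring at that carbon, as compound 1 does, the step expected for compound 3 is a 4.2-fold lower number from compound 2 to compound 3 (0.62 log units; beyond the scatter), back toward the number of compound 1. Compound 3 is therefore estimated at 18 nM, range 6 nM to 55 nM.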

Compound 3, half-maximal effective concentration: 89 nM
The estimate for compound 3 lay 4.9-fold (0.69 log units) below the measured number; the measured number lies above the stated range.
By their numbers in this assay, from the lowest: compound 1; then compounds 2 and 3 (each within the scatter of the next).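

In this assay the step is a 1.2-fold higher number from compound 2 to compound 3 (0.07 log units; within the scatter) and so a ring at this aromatic carbon does not by itself separate compound 3 from the open acetyl(methyl)amino group of compound 2. The 4-hydroxy-2-oxopiperidin-1-yl ring also does not match the five-membered ring of compound 1, the step being a 9.2-fold higher number from compound 1 to compound 3 (0.96 log units; beyond the scatter) and so compound 1 stays apart from both others. Nothing measured here explains this difference between the two rings.

Still open, as far as these compounds go, is whether the hydroxyl matters, as the unsubstituted 2-oxopiperidin-1-yl ring would show. A piperazine or a carboxylic acid on this carbon also remains to be placed against compound 1.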